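Acetoxymethyl to methoxymethyl on compound 1

The source may hold more compounds than are shown below. What is called first, only, known or untested is meant among the compounds shown, and "the series" means these compounds.

In a functional assay on MCF7 cells (Homo sapiens) for antiproliferative activity, read by MTT assay, with a stated time of 48 h (on this read-out lower numbers stand for stronger inhibition and higher numbers for weaker inhibition), compound 1 (`CC(=O)OC/C1=C/C[C@](C)(CCC=C(C)C)/C=C/[C@@H](OC(=O)C=C(C)C)[C@](C)(O)/C=C/C1=O`) gives 4510 nM and compound 2 (`CC(=O)OC/C1=C/C[C@](C)(CCC=C(C)C)/C=C/[C@@H](OC(=O)C=C(C)C)[C@](C)(OC(C)=O)/C=C/C1=O`) gives 3990 nM. Among the compounds with values here, these are the only two numbers, and they lie within the scatter of each other, so compound 1 stands level with its one neighbour. Compound 3 (`COC/C1=C/C[C@](C)(CCC=C(C)C)/C=C/[C@@H](OC(=O)C=C(C)C)[C@](C)(O)/C=C/C1=O`) has methyl in place of acetyl on an oxygen on a saturated carbon, turning acetoxymethyl into methoxymethyl: methyl in place of acetyl on an oxygen on a saturated carbon. Within the data shown here, only one measured step bears on this, and only indirectly, since it changes a different oxygen: a 1.1-fold lower number from compound 1 to compound 2 (0.05 log units; within the scatter). That step adds an acetyl and stays within the scatter. Among the measured compounds shown here, no measured step alters the acetoxymethyl group itself, so the evidence is thin. The expected change is a 1.1-fold higher number from compound 1 to compound 3 (0.04 log units; within the scatter), which is no step beyond the scatter in this assay. For compound 3 the estimated value is 5000 nM, with an expected range of 2200 nM to 11000 nM.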

Compound 3, half-maximal inhibitory concentration: 4130 nM
Estimate against measurement, compound 3: 1.2-fold (0.08 log units) above; the measured number falls inside the stated range.
By their numbers in this assay, from the lowest: compounds 2, 3 and 1 (each within the scatter of the next).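

Within the data shown here, this is the first direct reading on the acetoxymethyl group itself: in this assay the step is a 1.1-fold lower number from compound 1 to compound 3 (0.04 log units; within the scatter), whereas the earlier step concerned a different oxygen. Compounds 1 and 3 therefore stand level, so at this place methoxymethyl serves as well as acetoxymethyl, and the acetyl with its carbonyl is not needed to hold the number in this assay. Nothing in the data speaks to the reason for this.

From the compounds shown here alone, whether a hydroxymethyl, an aminomethyl or a longer ether such as benzyloxymethyl would stay level at this place remains open. Also open, going by these compounds, is whether methoxymethyl would behave the same way with the acetyl of compound 2 on the other oxygen.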